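The source may report more compounds than this note shows. Statements on the series, on what has been measured and on what is new or still open speak of the compounds shown alone.

In a functional assay on HSC-2 cells (Homo sapiens) for cytotoxicity, read by MTT assay (on this read-out lower numbers stand for stronger inhibition and higher numbers for weaker inhibition), compound 3 `COc1cc(CC[C@H](C[C@H](O)CCc2ccc(O)c(O)c2)O[C@@H]2O[C@H](CO)[C@@H](O)[C@H](O)[C@H]2O)ccc1O` gives 209 ug/mL, the highest of the three numbers, though all three lie within the scatter of one another. Compound 1 `OC[C@H]1O[C@@H](O[C@H](CCc2ccc(O)cc2)C[C@H](O)CCc2ccc(O)c(O)c2)[C@H](O)[C@@H](O)[C@@H]1O` gives 155 ug/mL in this assay, and compound 2 `COc1cc(CC[C@H](C[C@H](O)CCc2ccc(O)cc2)O[C@@H]2O[C@H](CO)[C@@H](O)[C@H](O)[C@H]2O)ccc1O` gives 160 ug/mL. The two steps that lead to compound 3 are both small: a 1.3-fold higher number from compound 1 to compound 3 (0.13 log units; within the scatter) and a 1.3-fold higher number from compound 2 to compound 3 (0.12 log units; within the scatter). Compound 4 `COc1cc(CC[C@@H](O)C[C@@H](CCc2ccc(O)c(OC)c2)O[C@@H]2O[C@H](CO)[C@@H](O)[C@H](O)[C@H]2O)ccc1O` differs from compound 3 by methyl in place of hydrogen on an oxygen on an aromatic ring. Neither measured step concerns a methyl on an aromatic oxygen, yet both show that small changes on the aromatic rings of this core leave the number almost unchanged. The step of a 1.0-fold lower number from compound 3 to compound 4 (0.01 log units; within the scatter) is therefore expected to stay within the scatter. Compound 4 is estimated at 205 ug/mL, with a range from 130 ug/mL to 330 ug/mL.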

Compound 4, half-maximal inhibitory concentration: 198 ug/mL
Beside the measured number, compound 4's estimate is 1.0-fold (0.02 log units) above it, and the stated range covers the measured number.
By their numbers in this assay, from the lowest: compounds 1, 2, 4 and 3 (each within the scatter of the next).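

Methyl in place of hydrogen on an oxygen on an aromatic ring, which turns 3,4-dihydroxyphenyl into 4-hydroxy-3-methoxyphenyl, gives a 1.1-fold lower number from compound 3 to compound 4 (0.02 log units; within the scatter), the first reading of this change in this assay. Methoxy in place of hydrogen on an aromatic carbon gives a 1.2-fold higher number from compound 2 to compound 4 (0.09 log units; within the scatter), and this change can now be read on two cores: the same change on two cores in this assay, a 1.3-fold higher number (0.13 log units; within the scatter) from compound 1 to compound 3 and a 1.2-fold higher number (0.09 log units; within the scatter) from compound 2 to compound 4, 1.1-fold (0.04 log units) apart, within the scatter of two such steps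

The compounds shown carry only hydrogen, hydroxy or methoxy at these places on the aromatic rings. They leave open whether an amine, a carboxylic acid or a longer chain on that oxygen would give a step beyond the scatter.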